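Three Limits and a Fourth Benzyl Variant

The compounds below may be only part of what the source reports. "The series", "measured", "known", "first", "only" and "open" are said of these compounds alone.

compound 1 `CCOC(=O)c1ccc(-c2nn(C)c3ccccc23)cc1`: > 10000 nM
compound 2 `CCOC(=O)c1ccc(-c2nn(Cc3ccccc3Cl)c3ccccc23)cc1`: > 10000 nM
compound 3 `CCOC(=O)c1ccc(-c2nn(Cc3ccc(F)cc3)c3ccccc23)cc1`: > 10000 nM

Three compounds share one core and differ only in the group carried on the saturated chain carbon bound to an aromatic nitrogen. In a functional assay on cells (Platelet, Homo sapiens) for inhibition (a lower number here means a stronger inhibitor, a higher number a weaker inhibitor), compound 1 reaches only a limit of the assay, > 10000 nM, not a measured number. Compound 2 likewise gives only a limit, > 10000 nM. Compound 3 also gives only a limit, > 10000 nM. Because every value sits at the limit of > 10000 nM in this assay, at which 3 of the 3 values shown sit, the steps between them cannot be sized: a step that the two limits leave unreadable from compound 1 to compound 2, a step that the two limits leave unreadable from compound 1 to compound 3 and a step that the two limits leave unreadable from compound 2 to compound 3 all remain unreadable.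

Compound 4 `CCOC(=O)c1ccc(-c2nn(Cc3ccccc3OC)c3ccccc23)cc1` is the next member of this set. It differs from compound 1 by 2-methoxyphenyl in place of hydrogen on a saturated chain carbon bound to an aromatic nitrogen. The two measured steps that resemble it, the move from compound 1 to compound 2 and the move from compound 1 to compound 3, each put an aromatic ring on the same carbon and each ended at the limit, so neither shows a readable gain or loss. With nothing pointing toward a measurable inhibitor, the expected step that the limit leaves unreadable from compound 1 to compound 4 is none beyond the scatter, with the result most likely another limit. The estimate for compound 4 in this assay is therefore 20000 nM, in the range 5000 nM to 100000 nM.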

Compound 4, half-maximal inhibitory concentration: > 10000 nM
Compound 4: no number, only a limit; the forecaster's own chance of this, stated with the estimate: 85%; the middle value does not contradict the limit.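

In this assay compound 4 gives > 10000 nM, a limit and not a number, so no step linking compound 4 with compound 1, compound 2 or compound 3 can be read: the limit of > 10000 nM in this assay, at which 4 of the 4 values shown sit.

The compounds shown leave open whether any group on this saturated chain carbon gives the shared core a measurable inhibition, and how far these four compounds truly differ.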